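The source may report more compounds than this note shows. Statements on the series, on what has been measured and on what is new or still open speak of the compounds shown alone.

Measured so far in an ADME assay on J774.A1 cells (Mus musculus) for cytotoxicity, read by MTT assay, with a stated time of 48 h; a higher number here means that more compound is tolerated, a lower number that less compound is tolerated:
Compound 1 `C/C(=C\c1ccccc1)C(=O)/C=C/c1ccc(N(C)C)cc1`: 20200 nM
Compound 2 `COc1ccc(/C=C/C(=O)/C(C)=C/c2ccc([N+](=O)[O-])cc2)cc1`: 36600 nM

The numbers for compound 2 and compound 1 lie within the usual scatter of each other, meaning the spread expected when one measurement is simply repeated. On these numbers, compound 2 cannot be told apart from compound 1.

The next compound to be tested is compound 3 `C/C(=C\c1ccc([N+](=O)[O-])cc1)C(=O)/C=C/c1ccc(N(C)C)cc1`, which differs from compound 2 in one place: dimethylamino in place of methoxy on an aromatic carbon. Put simply, this is dimethylamino in place of methoxy on an aromatic carbon, para to a large group.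

Among the measured compounds shown here, no pair of measured compounds differs in just one place, so no direct precedent exists for this change. The nearest guide is compound 1, which also carries dimethylamino and gives 20200 nM. No step beyond the scatter is therefore expected in this assay, and any direction is only a weak lean towards the lower number. The estimated step is a 1.4-fold lower number from compound 2 to compound 3 (0.13 log units; within the scatter). For compound 3, the expected value is 27000 nM, with an estimated range of 11000 nM to 60000 nM.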

Compound 3, half-maximal cytotoxic concentration: 24700 nM
Estimate against measurement, compound 3: 1.1-fold (0.04 log units) above; measured number inside the range.
By their numbers in this assay, from the lowest: compounds 1, 3 and 2 (each within the scatter of the next).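

In this assay the step of dimethylamino in place of methoxy on an aromatic carbon, para to a large group, is a 1.5-fold lower number from compound 2 to compound 3 (0.17 log units; within the scatter) and so cannot be told apart from simply repeating one measurement. Compound 3 also gives the first link to compound 1, and nitro in place of hydrogen on an aromatic carbon comes out as a 1.2-fold higher number from compound 1 to compound 3 (0.09 log units; within the scatter) and likewise stays inside what repetition alone would produce. With both single changes inside the scatter, these results give no sign that either one matters in this assay, and no measurement is available that would bear on them.

The compounds shown cover only methoxy and dimethylamino at the first place and only hydrogen and nitro at the second, so it remains open whether any group at either place can move the number beyond the scatter. What a carboxylic acid or a longer chain such as butoxy would do on the same aromatic carbon is an open question, and so is whether the same small steps would hold on a different core.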